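A few compounds are considered here, and "the series" means these few. Any claim that something is new, unique, unknown or untested is made for them only; others in the source may bear on it.

Measured so far:
compound 1 `Cc1cc(=O)oc2cc(OCCCn3cc(CNC(=O)CCCCC4CCSS4)nn3)ccc12`: 75.4%
compound 2 `COc1ccc(-c2cc3ccc(OCCCn4cc(CNC(=O)CCCCC5CCSS5)nn4)cc3oc2=O)cc1`: 65.7%
compound 3 `COc1ccc(-c2cc3ccc(OCCCCn4cc(CNC(=O)CCCCC5CCSS5)nn4)cc3oc2=O)cc1`: 55.3%

In a functional assay on PC-12 cells (Rattus norvegicus) for cytotoxicity, read by MTT assay, with stated times of 3 h and 2 h, tested at 50 uM (a lower number here means a weaker effect, a higher number a stronger effect of the compound at the concentration tested), compound 3 gives 55.3%, the lowest of the three numbers; compound 2 stands nearest, a step above it that is beyond the usual scatter, and compound 1 stands furthest, also beyond the scatter. Among the compounds with values here, no two measured compounds differ in a single place, so no measured step is known. Compound 4 `O=C(CCCCC1CCSS1)NCc1cn(CCCCOc2ccc3cc(-c4ccc(Cl)c(Cl)c4)c(=O)oc3c2)nn1` is not yet measured. It differs from compound 3 in one place: 3,4-dichlorophenyl in place of 4-methoxyphenyl on an aromatic carbon. Within the data shown here, no measured compound carries an exchange of this kind. In this assay a step of modest size is expected, upward if anything, and not clearly beyond the scatter; the expected step is a number 4.7 percentage points higher from compound 3 to compound 4 (within the scatter). Compound 4 is expected to give 60%, within 42% to 78%.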

Compound 4, a percentage reported as activity, at one concentration (the size of the read-out at that concentration, not a potency): 69.5%
Compound 4: the middle estimate sits 9.5 percentage points below what was measured, within the range that was stated.
By their numbers in this assay, from the lowest: compound 3; then compounds 2, 4 and 1 (each within the scatter of the next).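

In this assay, within the data shown here, 3,4-dichlorophenyl in place of 4-methoxyphenyl gives the first readable step, a number 14.2 percentage points higher from compound 3 to compound 4 (beyond the scatter), so the number responds to the aryl group at this position. The exchange removes the methoxy group and brings in chlorine, and this single step does not separate those two parts. Nothing measured on these compounds offers a cause for the step.

Going by these compounds, whether a single chlorine, or an amine or a carboxylic acid on the phenyl ring, gives a similar step remains open. Also open, on these data alone, is whether the same exchange holds with the chain of compound 2.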